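A few compounds are considered here, and "the series" means these few. Any claim that something is new, unique, unknown or untested is made for them only; others in the source may bear on it.

In an assay for inhibition of Polyunsaturated fatty acid 5-lipoxygenase (Homo sapiens), read by HPLC, with stated times of 15 min and 10 min (a lower number here means a stronger inhibitor, a higher number a weaker inhibitor), the three measured compounds stand as follows:

compound 1, `CC(C#Cc1cccc(C(=O)NCc2ccccc2OC(F)(F)F)c1)N(O)C(N)=O`, 1000 nM
compound 2, `CCCC(C#Cc1cccc(C(=O)NCc2ccccc2C(F)(F)F)c1)N(O)C(N)=O`, 300 nM
compound 3, `CC(C#Cc1cccc(C(=O)NCc2ccccc2C(F)(F)F)c1)N(O)C(N)=O`, 700 nM

Compound 3 gives the second highest of the three numbers. Its nearest neighbour is compound 1: the step of a 1.4-fold lower number from compound 1 to compound 3 (0.15 log units; within the scatter). Compound 2 lies furthest from it: the step of a 2.3-fold higher number from compound 2 to compound 3 (0.37 log units; beyond the scatter) shows a modest difference that goes beyond the scatter.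

Compound 4, `Cc1ccc(C(=O)NCc2ccccc2C(F)(F)F)cc1C#CC(C)N(O)C(N)=O`, has not yet been measured. It differs from compound 3 in one place: methyl in place of hydrogen on an aromatic carbon. Neither of the measured steps touches an aromatic carbon of that ring in this way. The step from compound 1 to compound 3 exchanges one substituent on the other aromatic ring for another, and the step from compound 2 to compound 3 shortens the saturated chain; neither tells how a methyl on the central ring will act. With nothing that bears directly on the change, the expectation for compound 4 is a step of about a 1.2-fold lower number from compound 3 to compound 4 (0.07 log units; within the scatter), that is, no shift beyond the scatter in either direction. Compound 4 is therefore estimated at 600 nM, with a range from 200 nM to 1800 nM.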

Compound 4, half-maximal inhibitory concentration: 1700 nM
Compound 4: middle estimate off by 2.8-fold (0.45 log units), on the low side; the measured number falls inside the stated range.
By their numbers in this assay, from the lowest: compound 2; then compounds 3, 1 and 4 (each within the scatter of the next, the first and the last beyond it).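

In this assay, the position on the aromatic carbon ortho to the 3-(carbamoyl(hydroxy)amino)but-1-yn-1-yl group and para to a large group proves sensitive to substitution: methyl in place of hydrogen gives a 2.4-fold higher number from compound 3 to compound 4 (0.39 log units; beyond the scatter), a modest shift towards weaker inhibition. The earlier steps shown here had changed only the substituent on the other aromatic ring and the saturated chain, so they showed nothing about this ring; here a single added carbon moves the number upwards, whereas a 2.3-fold higher number from compound 2 to compound 3 (0.37 log units; beyond the scatter) shows that compound 2, with its longer saturated chain, has the lower number. Nothing shown accounts for the loss at this position.

A single substituent at this carbon cannot show whether the shift follows from methyl alone or would also appear with fluorine, chlorine, methoxy or ethyl there. As far as these compounds go, it also remains open whether the same methyl would raise the number to a similar extent on the longer saturated chain of compound 2 or alongside the trifluoromethoxy group of compound 1.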